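Removing the urea nitrogen: an amide analogue of compound 2

The source may report more compounds than this note shows. Statements on the series, on what has been measured and on what is new or still open speak of the compounds shown alone.

Compound 2 `COc1cc(Cl)cc(-c2nn(-c3cccc(NC(=O)Nc4cccc(C(F)(F)F)c4)c3)cc2-c2ccncc2)c1` and compound 1 `COc1cc(Cl)cc(-c2nn(-c3cccc(NC(=O)Nc4ccc(Cl)c(C(F)(F)F)c4)c3)cc2-c2ccncc2)c1` share one core and were both tested in a functional assay on SF-268 cells (Homo sapiens) for inhibition, read by sulforhodamine B assay, with a stated time of 48 h, tested at 1 uM; a lower number here means a stronger effect, a higher number a weaker effect of the compound at the concentration tested. In this assay compound 1 gives 83%, and compound 2 gives 79%. Going by the values given here, the only measured step, a number 4 percentage points lower from compound 1 to compound 2 (within the scatter), separates them, so compound 2 stands beside compound 1 with no difference beyond the scatter. Compound 3 `COc1cc(Cl)cc(-c2nn(-c3cccc(NC(=O)c4cccc(C(F)(F)F)c4)c3)cc2-c2ccncc2)c1` has not been measured. It differs from compound 2 by 3-(trifluoromethyl)phenyl in place of (3-(trifluoromethyl)phenyl)amino on a carbonyl carbon. Among the compounds with values here, no measured step touches this part of the structure; the one step known, from compound 1 to compound 2, concerns a different place and was itself within the scatter. With nothing pointing in either direction, the expected step of a number 1 percentage points higher from compound 2 to compound 3 (within the scatter) is estimated to remain within the scatter. Compound 3 is therefore expected to give about 80% in this assay, estimated to fall between 62% and 96%.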

Compound 3, a percentage reported as activity, at one concentration (the size of the read-out at that concentration, not a potency): 100%
Beside the measured number, compound 3's estimate is 20 percentage points below it; measured number outside the range, above it.
By their numbers in this assay, from the lowest: compounds 2 and 1 (each within the scatter of the next); then compound 3.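

In this assay, going by these compounds alone, the change on the carbonyl carbon is the first to move the read-out beyond the scatter, with a number 21 percentage points higher from compound 2 to compound 3 (beyond the scatter) and a number 17 percentage points higher from compound 1 to compound 3 (beyond the scatter). Since a higher number means a weaker effect, compound 3 is the weakest of the three at the concentration tested, so this position responds to change in a way the chloro step did not show. The change removes the amino nitrogen and its one hydrogen-bond donor, but nothing measured here explains the step.

Going by these compounds, it remains open whether the step depends on that nitrogen specifically, which a methylene group or an oxygen atom in its place would test. On these data alone, it is also open whether an amide carrying 4-chloro-3-(trifluoromethyl)phenyl would follow compound 3.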